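The source may hold more compounds than are shown below. What is called first, only, known or untested is meant among the compounds shown, and "the series" means these compounds.

Measured so far:
Compound 1 `C[C@H](NC1=CC(=O)C=C(C(C)(C)C)C1=O)C(=O)O` was tested in a functional assay on A549 cells (Homo sapiens) for cytotoxicity, read by MTT assay, with a stated time of 72 h; on this read-out higher numbers stand for weaker inhibition and lower numbers for stronger inhibition; compound 1 gives > 200000 nM, which is a limit of the assay and not a number.
Compound 2 `CC1=CCC[C@H]2[C@](C)(CC3=CC(=O)C=C(N[C@@H](CC(C)C)C(=O)O)C3=O)[C@@H](C)CC[C@]12C` gives 19700 nM.
Compound 3 `CC(C)(C)C1=CC(=O)C=C(NCCC(=O)O)C1=O` gives 171000 nM.

Compound 2 has the lowest of the two numbers shown, and compound 3 stands well above it. Within the data shown here, the only step measured between compounds, an at least 1.1-fold lower number from compound 1 to compound 3 (0.06 log units; that floor lies within the scatter), concerns a different change on a different core, and one of its ends is a limit (the limit of > 200000 nM in this assay, at which 1 of the 3 values shown sits), so it gives no size to carry over. Compound 4 `CC1=CCC[C@H]2[C@](C)(CC3=CC(=O)C=C(N[C@@H](C)C(=O)O)C3=O)[C@@H](C)CC[C@]12C` keeps the core of compound 2 and differs from it by hydrogen in place of isopropyl on a saturated chain carbon, two bonds along the chain from an amine nitrogen and a carbonyl carbon. Among the measured compounds shown here, no measured pair shows this change, so there is nothing to fix its direction; the side chain shrinks, and the expectation is for a small rise in the number, a 1.8-fold higher number from compound 2 to compound 4 (0.25 log units; within the scatter), which stays near the scatter. Compound 4 is therefore estimated at 35000 nM, with a range from 12000 nM to 100000 nM.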

Compound 4, half-maximal inhibitory concentration: 54300 nM
Compound 4: middle estimate off by 1.6-fold (0.19 log units), on the low side; measured number inside the range.
By their numbers in this assay, from the lowest: compound 2; then compound 4; then compound 3. At a limit, above all of these: compound 1.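

Cutting isobutyl back to methyl on the shared core gives, in this assay, a 2.8-fold higher number from compound 2 to compound 4 (0.44 log units; beyond the scatter) and so puts a first size on a change at this chain carbon. Among these compounds, the only earlier step sat on a different core, involved a different change and had a limit at one end, whereas this one joins two real numbers. On this core, then, the isobutyl chain goes with the lower number, though the step is modest, and the data shown hold nothing that explains the rise.

From the compounds shown here alone, whether a chain of intermediate length such as ethyl, a longer chain or a benzyl group would go further in the same direction stays open. So does whether isobutyl in place of methyl would move the number in the same direction on the core of compound 1.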